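This account rests on a few compounds, and the source may have more. Where it says the series, first, only, none or still open, it means among the compounds named here.

Working notes on the series. In a functional assay on HCT-116 cells (Homo sapiens) for inhibition, read by sulforhodamine B assay, with a stated time of 48 h, tested at 50 uM (a lower number here means less inhibition of growth, a higher number more inhibition of growth at the concentration tested), compound 1 (`COc1cc(/C=C/C(=O)/C=C/c2cccc3ccccc23)ccc1OCc1cn(CCCCCOc2cc(=O)oc3ccccc23)nn1`) gives 42% and compound 2 (`COc1cc(/C=C/C(=O)/C=C/c2cccc3ccccc23)ccc1OCc1cn(CCCCOc2cc(=O)oc3ccccc23)nn1`) gives 56% at the single concentration tested. For the measured compounds named here, compound 2 therefore holds the higher of the two numbers so far, and its gap to compound 1 lies beyond the usual scatter. Two values are a thin base, and no pattern is claimed from them.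

The next compound is compound 3 (`COc1ccc(/C=C/C(=O)/C=C/c2ccc(OCc3cn(CCCCOc4cc(=O)oc5ccccc45)nn3)c(OC)c2)cc1`). It carries 4-methoxyphenyl in place of naphthalen-1-yl on a double-bonded chain carbon bound to a double-bonded chain carbon. Going by the values given here, the series holds no measured example of this exchange, so the expectation starts from compound 2 at 56% and stays cautious. A modest fall in this assay is expected, and the estimated change (a number 8 percentage points lower from compound 2 to compound 3 (within the scatter)) is of about the size of the usual scatter, so a result with no real change would not surprise. Compound 3 is estimated at 48% in this read-out, with an expected range from 30% to 66% around that figure.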

Compound 3, percent growth inhibition at one concentration: 40%
For compound 3 the middle estimate is 8 percentage points above the measured one, within the range that was stated.
By their numbers in this assay, from the lowest: compounds 3 and 1 (each within the scatter of the next); then compound 2.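

For the compounds shown here, the exchange of naphthalen-1-yl for 4-methoxyphenyl on a double-bonded chain carbon bound to a double-bonded chain carbon in this assay gives a number 16 percentage points lower from compound 2 to compound 3 (beyond the scatter) and is the first measured change at this position. The position therefore matters in this read-out: a group with two six-membered aromatic rings and 10 heavy atoms gives way to one with a single such ring, 8 heavy atoms and one hydrogen-bond acceptor, and growth inhibition at the tested concentration falls. Nothing measured on these compounds accounts for the fall, and this single step cannot separate the loss of the second ring from the entry of the methoxy group.

A plain phenyl at this position would help to tell those two parts of the exchange apart, and a 4-hydroxyphenyl or a phenyl ring carrying an amine would show how far the read-out follows other substituents. On these data alone, it also remains open whether the same exchange gives a step of similar size on the longer chain of compound 1, and whether the result at one concentration holds across a full concentration range.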